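A few compounds are considered here, and "the series" means these few. Any claim that something is new, unique, unknown or untested is made for them only; others in the source may bear on it.

In a physicochemical assay for lipophilicity, at pH 7.4 (a higher number here means a more lipophilic compound, a lower number a more polar compound), compound 1 (`CN(C)C(=O)C1CCN(c2cncnc2-c2ccccc2)CC1`) gives 1.7 and compound 2 (`CN(C)C(=O)C1CCN(c2cncnc2-c2ccc(F)cc2)CC1`) gives 1.9 while compound 3 (`CN(C)C(=O)C1CCN(c2cnccc2-n2cccn2)CC1`) gives 1.1 and stands lowest of the three, beyond the scatter from both. Compound 4 (`CN(C)C(=O)C1CCN(c2cnccc2-n2cc(Br)cn2)CC1`) is still unmeasured. It carries bromo in place of hydrogen on an aromatic carbon, turning 1H-pyrazol-1-yl into 4-bromo-1H-pyrazol-1-yl (bromo in place of hydrogen on an aromatic carbon). Within the data shown here, the only measured step of a similar kind is the fluoro replacement, a number 0.20 log units higher from compound 1 to compound 2 (within the scatter) and that step sits elsewhere in the structure. Among the measured compounds shown here, no bromo step has been measured, so it offers only a weak guide to direction, and a larger step is judged likely. The expected change is a number 0.70 log units higher from compound 3 to compound 4 (beyond the scatter) in this assay and would lie beyond the scatter. Compound 4 is estimated at 1.8 with 1.4 to 2.2 as its expected range.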

Compound 4, distribution coefficient: 2.1
Beside the measured number, compound 4's estimate is 0.30 log units below it; low and high end bracket the measured number.
By their numbers in this assay, from the lowest: compound 3; then compounds 1, 2 and 4 (each within the scatter of the next, the first and the last beyond it).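

On an aromatic carbon of the five-membered aromatic ring with 2 nitrogen, two ring bonds from the ring nitrogen, bromo in place of hydrogen gives a number 1.00 log units higher from compound 3 to compound 4 (beyond the scatter) in this assay. This is the first single-place halogen change shown to pass the scatter, whereas the fluoro change elsewhere in the structure, a number 0.20 log units higher from compound 1 to compound 2 (within the scatter), does not. Nothing measured here accounts for the size of the bromo step. The compounds shown leave open whether chloro, methyl or a nitrile on this carbon would move the number as far. They also leave open whether the size of this step belongs to bromo itself or to this position.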